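A few compounds are considered here, and "the series" means these few. Any claim that something is new, unique, unknown or untested is made for them only; others in the source may bear on it.

Working notes on the series. In a functional assay on A549 cells (Homo sapiens) for antiproliferative activity, read by MTT assay, with a stated time of 48 h (a lower number here means a stronger inhibitor, a higher number a weaker inhibitor), compound 1 `COc1ccc(-c2nn(-c3ccccc3)cc2C(Nc2nc3ccc(OC)cc3s2)c2c(O)ccc3ccccc23)cc1` gives 28100 nM and compound 2 `COc1ccc2nc(NC(c3cn(-c4ccccc4)nc3-c3cccc([N+](=O)[O-])c3)c3c(O)ccc4ccccc34)sc2c1` gives 52200 nM, so these two values lie within the scatter of each other. Compound 3 `COc1ccc2nc(NC(c3cn(-c4ccccc4)nc3-c3cccc(I)c3)c3c(O)ccc4ccccc34)sc2c1` has not yet been measured. It departs from compound 2 by one change, iodo in place of nitro on an aromatic carbon, meta to a large group: iodo in place of nitro on an aromatic carbon. In short, 3-nitrophenyl becomes 3-iodophenyl. For the measured compounds named here, only one measured step bears on this, the one that introduced the 3-nitrophenyl group: a 1.9-fold higher number from compound 1 to compound 2 (0.27 log units; within the scatter). Going by the values given here, no measured compound carries iodo, so the evidence is thin and the range must stay wide. No step beyond the scatter is expected in this assay because a 1.9-fold higher number from compound 1 to compound 2 (0.27 log units; within the scatter) stayed within it. The expected step is a 1.3-fold lower number from compound 2 to compound 3 (0.12 log units; within the scatter). For compound 3 the estimated value is 40000 nM, with an expected range of 16000 nM to 95000 nM.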

Compound 3, half-maximal inhibitory concentration: 39300 nM
For compound 3 the middle estimate is 1.0-fold (0.01 log units) above the measured one, within the range that was stated.
By their numbers in this assay, from the lowest: compounds 1, 3 and 2 (each within the scatter of the next).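

In this assay, iodo in place of nitro gives a 1.3-fold lower number from compound 2 to compound 3 (0.12 log units; within the scatter), so this position on the six-membered aromatic ring, meta to a large group, tolerates the loss of the nitro group, with its hydrogen-bond acceptors and its double bond, without a step beyond the scatter. The second step that reaches the new compound, a 1.4-fold higher number from compound 1 to compound 3 (0.15 log units; within the scatter), also stays within the scatter, so 4-methoxyphenyl, 3-nitrophenyl and 3-iodophenyl cannot be told apart in this assay. No measured property of these groups is available to interpret the result.

On these data alone, whether an amine or a carboxylic acid in the same place would give a step beyond the scatter remains open. Also open, as far as these compounds go, is whether iodo and nitro would remain indistinguishable on a different core.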